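This account rests on a few compounds, and the source may have more. Where it says the series, first, only, none or still open, it means among the compounds named here.

Measured compounds:
- compound 1, `CCOC(=O)C1=C(C)N/C(=C/c2cc(C)n(-c3ccncc3)c2C)C1=O`: in an ADME assay on L6 cells (Rattus norvegicus) for cytotoxicity, read by resazurin assay, with a stated time of 72 h (on this read-out lower numbers stand for an effect already at smaller amounts and higher numbers for an effect only at larger amounts of compound), compound 1 gives 100000 nM
- compound 2, `CC1=C(C(=O)O)C(=O)/C(=C\c2cc(C)n(-c3ccccc3C(F)(F)F)c2C)N1`: in this assay compound 2 gives 31000 nM

Of these two numbers, compound 2 stands at the lower one; compound 1 sits higher, and the gap between them lies beyond the usual scatter. Both compounds share the same core and differ only in the group on the ring nitrogen and in the ester against the free acid.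

Compound 3, `CC1=C(C(=O)N2CCCCC2)C(=O)/C(=C\c2cc(C)n(-c3ccccc3C(F)(F)F)c2C)N1`, keeps the core of compound 2 and changes it at one place: piperidin-1-yl in place of hydroxy on a carbonyl carbon. Going by the values given here, no pair among the measured compounds shows this kind of change, so the size of the step is not known from the data. The step in this assay is expected to be a small to moderate one toward lower numbers, and it may well fall within the scatter. Compound 3 is therefore estimated at 15000 nM, with a range from 5000 nM to 50000 nM. This estimate means an expected step of a 2.1-fold lower number from compound 2 to compound 3 (0.32 log units; beyond the scatter).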

Compound 3, half-maximal effective concentration: 26000 nM
Compound 3: the middle estimate sits 1.7-fold (0.24 log units) below what was measured; measured number inside the range.
By their numbers in this assay, from the lowest: compounds 3 and 2 (each within the scatter of the next); then compound 1.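

Going by these compounds alone, the pair of compound 2 and compound 3 is the first to isolate a single place, the carbonyl carbon on the double-bonded ring carbon: in this assay, piperidin-1-yl in place of hydroxy gives a 1.2-fold lower number from compound 2 to compound 3 (0.08 log units; within the scatter). On this read-out, carboxy and (piperidin-1-yl)carbonyl therefore cannot be told apart here, although the change adds a six-membered non-aromatic ring and removes the hydrogen-bond donor of hydroxy. Nothing available explains this result.

The compounds shown leave open whether the same holds for other groups on this carbonyl carbon, such as morpholin-4-yl, dimethylamino or an ethoxy group on the core of compound 2. Within the data shown here, they also leave the group on the ring nitrogen unresolved, as no pair changes it alone.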